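The compounds below may be only part of what the source reports. "The series", "measured", "known", "first", "only" and "open" are said of these compounds alone.

Measured compounds:
compound 1 `CNC(=O)CC1CCc2cc(OC)c(OC)cc21`, 33.3%
compound 2 `COc1cc2c(cc1OC)C(CC(=O)NC(C)C)CC2`, 30%
compound 3 `CCCCCCNC(=O)CC1CCc2cc(OC)c(OC)cc21`, 45.5%

In a functional assay on the whole organism (strain Wistar) for inhibition, with Rattus norvegicus as the target, read by paw edema, with stated times of 60 min and 24 h, at a dose of 100 mg/kg by the oral route (a lower number here means less inhibition, a higher number more inhibition at the dose given (going by the name of the read-out)), compound 2 gives 30%, the lowest of the three numbers, though its gap to compound 1 is within the scatter; only compound 3 stands apart from it, beyond the scatter.

The unmeasured compound 4 `COc1cc2c(cc1OC)C(CC(=O)N1CCCC1)CC2` differs from compound 2 in one place: pyrrolidin-1-yl in place of isopropylamino on a carbonyl carbon. The amide nitrogen thus loses its isopropyl group and its hydrogen and becomes part of a five-membered non-aromatic ring.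

Within the data shown here, two measured steps bear on what the amide nitrogen substituent does here: a number 12.2 percentage points higher from compound 1 to compound 3 (beyond the scatter) and a number 15.5 percentage points higher from compound 2 to compound 3 (beyond the scatter), both modest rises with a longer chain on the nitrogen, whereas a number 3.3 percentage points lower from compound 1 to compound 2 (within the scatter), a branching of the small alkyl, stays within the scatter. Among the measured compounds shown here, no measured step shows a ring closed onto the amide nitrogen or the loss of the amide hydrogen, so the data give no direct guide for that part of the change. Pyrrolidin-1-yl is counted at five heavy atoms, closer to isopropylamino than to the hexyl chain of compound 3, so a step of a number 6 percentage points higher from compound 2 to compound 4 (within the scatter) is expected, which is a change within the scatter or at most a small rise.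

Compound 4 is therefore estimated at 36% in this assay, with a range from 22% to 50%.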

Compound 4, a percentage reported as inhibition, in the whole organism at one dose (the size of the read-out at that dose, not a potency): 33.3%
Compound 4: middle estimate off by 2.7 percentage points, on the high side, and the stated range covers the measured number.
By their numbers in this assay, from the lowest: compounds 2, 1 and 4 (each within the scatter of the next); then compound 3.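

Working notes on the amide nitrogen: in this assay, replacing isopropylamino on the carbonyl carbon with pyrrolidin-1-yl gives a number 3.3 percentage points higher from compound 2 to compound 4 (within the scatter), and replacing methylamino gives no change at the digits printed from compound 1 to compound 4 (within the scatter), so closing the nitrogen into a five-membered ring and removing the amide hydrogen leaves the read-out within the scatter of both small secondary amides. Set against the hexylamino chain, the same ring gives a number 12.2 percentage points lower from compound 3 to compound 4 (beyond the scatter), so the hexylamino group remains the only substituent at this carbonyl carbon that stands apart from the others, and the amide hydrogen is not required to retain the level of inhibition seen with the small secondary amides at this dose. No measured property of these compounds is available to account for any of these steps.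

Still open, as far as these compounds go, is whether a larger ring, such as piperidin-1-yl or morpholin-4-yl, stays at the level of the pyrrolidin-1-yl amide or moves towards the hexylamino amide. Also open, from the compounds shown here alone, is how a butylamino or octylamino chain, or a dihexylamino group without the amide hydrogen, would compare with the hexylamino amide.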